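From Fluorophenyl to Iodophenyl in a Series Without Activity

The source may report more compounds than this note shows. Statements on the series, on what has been measured and on what is new or still open speak of the compounds shown alone.

Measured so far:
Compound 1 `O=C(Nc1ccc(Br)cc1)N1CCC[C@H]1c1nc(-c2ccccc2)no1` gives > 50000 nM
Compound 2 `N#Cc1ccc(NC(=O)N2CCC[C@H]2c2nc(-c3ccccc3)no2)cc1` gives > 50000 nM
Compound 3 `O=C(Nc1ccc(Cl)cc1)N1CCC[C@H]1c1nc(-c2cccc(F)c2)no1` gives > 50000 nM

In an ADME assay on MCF-10A cells (Homo sapiens) for inhibition, with a stated time of 48 h (a lower number here means a stronger inhibitor, a higher number a weaker inhibitor), compound 1 sits at a limit of the assay, not a number. Compound 2 likewise sits at a limit. Compound 3 also sits at a limit, so its standing among the three is only that it is at the limit of > 50000 nM in this assay, at which 3 of the 3 values shown sit, together with the others. Within the data shown here, the one step between measured compounds, a step that the two limits leave unreadable from compound 1 to compound 2, is therefore unreadable.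

Compound 4 `O=C(Nc1ccc(Cl)cc1)N1CCC[C@H]1c1nc(-c2ccc(I)cc2)no1` differs from compound 3 by 4-iodophenyl in place of 3-fluorophenyl on an aromatic carbon. Among the measured compounds shown here, no measured step touches this change, and every value shown is a limit, so no step beyond the scatter can be read from the data. Compound 4 is therefore expected to sit at the same limit, with an estimate of 80000 nM, range 30000 nM to 300000 nM, meaning an expected step that the limit leaves unreadable from compound 3 to compound 4.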

Compound 4, half-maximal inhibitory concentration: > 50000 nM
Compound 4: no number, only a limit; the forecaster's own chance of this, stated with the estimate: 85%; the middle value is on the limit's open side.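

In this assay, among these compounds, compound 4 gives > 50000 nM, a limit and not a number, as compound 3 does, so no step between compound 3 and compound 4 can be read. Still open is whether any of these group changes alters inhibition, as every value shown rests on one limit: the limit of > 50000 nM in this assay, at which 4 of the 4 values shown sit.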